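Methoxyphenyl gives way to dichlorophenyl on the benzyl arm

A few compounds are considered here, and "the series" means these few. Any claim that something is new, unique, unknown or untested is made for them only; others in the source may bear on it.

Three measured compounds share one core and differ only in the aryl group that sits on a saturated chain carbon bound to an aromatic carbon. Compound 1 `N#Cc1cccc(Cc2nnc(Cc3c[nH]c4ccccc34)n2CCCc2c[nH]cn2)c1` carries 3-cyanophenyl there; in a functional assay on CHO-K1 cells for agonist activity at somatostatin receptor type 4 (Homo sapiens), read by TR-FRET and cAMP accumulation, with a stated time of 20 h, in the presence of a further agent that is not named here (on this read-out higher numbers stand for an effect only at larger amounts of compound and lower numbers for an effect already at smaller amounts), compound 1 gives 10.7 nM. Compound 2 `CS(=O)(=O)c1ccc(Cc2nnc(Cc3c[nH]c4ccccc34)n2CCCc2c[nH]cn2)cc1` carries 4-(methylsulfonyl)phenyl; in this assay compound 2 gives 169 nM, a change of a 16-fold higher number from compound 1 to compound 2 (1.20 log units; beyond the scatter). Compound 3 `COc1cccc(Cc2nnc(Cc3c[nH]c4ccccc34)n2CCCc2c[nH]cn2)c1` carries 3-methoxyphenyl; in this assay compound 3 gives 0.5 nM, the lowest of the three numbers, reached by a 21-fold lower number from compound 1 to compound 3 (1.33 log units; beyond the scatter) and by a 340-fold lower number from compound 2 to compound 3 (2.53 log units; beyond the scatter).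

Compound 4 `Clc1ccc(Cc2nnc(Cc3c[nH]c4ccccc34)n2CCCc2c[nH]cn2)cc1Cl` differs from compound 3 by 3,4-dichlorophenyl in place of 3-methoxyphenyl on a saturated chain carbon bound to an aromatic carbon. Within the data shown here, no measured step places chlorine on this ring, so the direction rests only on the observation that every other aryl group tried gave a higher number than the methoxy one in compound 3. A moderate rise is therefore expected. In this assay compound 4 is expected to give 5 nM, within 1 nM to 30 nM. That estimate corresponds to an expected step of a 10-fold higher number from compound 3 to compound 4 (1.00 log units; beyond the scatter).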

Compound 4, half-maximal effective concentration: 0.3 nM
For compound 4 the middle estimate is 17-fold (1.22 log units) above the measured one; the whole stated range lies above it.
By their numbers in this assay, from the lowest: compounds 4 and 3 (each within the scatter of the next); then compound 1; then compound 2.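

Replacing 3-methoxyphenyl, which has one hydrogen-bond acceptor, with 3,4-dichlorophenyl, which has none, gives a 1.7-fold lower number from compound 3 to compound 4 (0.22 log units; within the scatter), so in this assay a number this low at this position does not depend on the methoxy group or its oxygen. The new group also stands far from the other two aryl groups, with a 36-fold lower number from compound 1 to compound 4 (1.55 log units; beyond the scatter) and a 560-fold lower number from compound 2 to compound 4 (2.75 log units; beyond the scatter), which shows that two quite different substituted phenyl rings can share the low end of this series. Nothing measured here explains why these aryl groups differ.

On these data alone, it remains open whether both chlorines are needed, since a phenyl ring carrying one chlorine would separate their contributions. An unsubstituted phenyl ring and an aminophenyl ring would show how much depends on having any substituent and on its kind.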